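This account rests on a few compounds, and the source may have more. Where it says the series, first, only, none or still open, it means among the compounds named here.

Of the compounds shown here, three built on one shared core have been measured in a functional assay on the whole organism (6C3HED cells, Mus musculus) for inhibition, at a dose of 150 mg/kg by the oral route; a lower number here means less inhibition, a higher number more inhibition at the dose given (going by the name of the read-out). Compound 1 `COc1ccc(S(=O)(=O)NC(=O)Nc2ccc(Cl)cc2)s1` gives 93% in this assay, compound 2 `CCc1ccc(S(=O)(=O)NC(=O)Nc2ccc(Cl)cc2)s1` gives 57% and compound 3 `CCCc1ccc(S(=O)(=O)NC(=O)Nc2ccc(Cl)cc2)s1` gives 38%. Compound 3 thus stands lowest of the three, with compound 2 nearest to it and compound 1 furthest away. The steps among them all point the same way: a number 36 percentage points lower from compound 1 to compound 2 (beyond the scatter) and a number 55 percentage points lower from compound 1 to compound 3 (beyond the scatter), both large, and a number 19 percentage points lower from compound 2 to compound 3 (beyond the scatter), which is modest.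

Compound 4 `CC(C)c1ccc(S(=O)(=O)NC(=O)Nc2ccc(Cl)cc2)s1` has not yet been measured in this assay. It differs from compound 3 in one place: isopropyl in place of propyl on an aromatic carbon. The two compounds hold the same atoms joined differently, so the change is not a lengthening of the chain but a rearrangement of it. For the measured compounds named here, none of the measured steps tests such a rearrangement: the steps from compound 1 to compound 2 and from compound 1 to compound 3 exchange methoxy for ethyl or propyl, and the step from compound 2 to compound 3 extends the chain. With the chain neither lengthened nor shortened, compound 4 is expected to show a step of a number 2 percentage points higher from compound 3 to compound 4 (within the scatter) in this assay, which lies within the scatter. The estimated value for compound 4 is 40%, with a range from 20% to 60%.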

Compound 4, a percentage reported as inhibition, in the whole organism at one dose (the size of the read-out at that dose, not a potency): 42%
For compound 4 the middle estimate is 2 percentage points below the measured one; the measured number falls inside the stated range.
By their numbers in this assay, from the lowest: compounds 3 and 4 (each within the scatter of the next); then compound 2; then compound 1.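

In this assay, for the compounds shown here, isopropyl in place of propyl on the aromatic carbon next to the ring sulfur gives a number 4 percentage points higher from compound 3 to compound 4 (within the scatter) and so, unlike the earlier steps, shows that rearranging these three carbons from a straight chain to a branched one leaves the read-out within the scatter at this position. The earlier compounds had shown a methyl added only at the far end of the chain, whereas a methyl on the chain carbon bound to the aromatic carbon gives a number 15 percentage points lower from compound 2 to compound 4 (beyond the scatter) in this modest step, which runs the same way as a number 19 percentage points lower from compound 2 to compound 3 (beyond the scatter) at the end of the chain, so both ways of adding a carbon to ethyl lead downward. Set against methoxy, isopropyl gives a number 51 percentage points lower from compound 1 to compound 4 (beyond the scatter) as a large step, so the branched group joins ethyl and propyl in falling well short of compound 1 at this dose.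

Nothing given here bears on why these numbers fall as they do. On these data alone, it remains open whether a longer chain such as butyl, a more branched group such as tert-butyl, or an oxygen-linked group such as ethoxy on this carbon would stay with compound 3 and compound 4 or come closer to compound 1.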